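The source may hold more compounds than are shown below. What is called first, only, known or untested is meant among the compounds shown, and "the series" means these compounds.

Compound 3 `Cn1nc2c(=O)n(CC3(O)CCN(Cc4ccc(-c5ccc(C(=O)O)o5)cc4Cl)CC3)cnc2c1-c1ccc(CN)cc1` is the weakest of the three measured compounds: in an assay on isolated protein for inhibition of ubiquitin carboxyl-terminal hydrolase 7 (Homo sapiens), with stated times of 30 min and 2 h (a lower number here means a stronger inhibitor, a higher number a weaker inhibitor), compound 3 gives 753 nM, while compound 2 `Cn1nc2c(=O)n(CC3(O)CCN(Cc4ccc(-c5ccc[nH]5)cc4Cl)CC3)cnc2c1-c1ccc(CN)cc1` gives 193 nM and compound 1 `Cn1nc2c(=O)n(CC3(O)CCN(Cc4ccc(-c5ccco5)cc4Cl)CC3)cnc2c1-c1ccc(CNCCO)cc1` gives 8.2 nM. Compound 4 `Cn1nc2c(=O)n(CC3(O)CCN(Cc4ccc(-c5ccco5)cc4Cl)CC3)cnc2c1-c1ccc(CN)cc1` differs from compound 3 in a single place (hydrogen in place of carboxy on an aromatic carbon), so that 5-carboxyfuran-2-yl becomes furan-2-yl. Among the compounds with values here, no measured pair shows exactly this change. The closest guide is a 3.9-fold higher number from compound 2 to compound 3 (0.59 log units; beyond the scatter), where 5-carboxyfuran-2-yl in place of 1H-pyrrol-2-yl gave a higher number, and compound 1, which carries furan-2-yl and has the lowest number shown. Removing the carboxy is therefore expected to lower the number, by about a 6.3-fold lower number from compound 3 to compound 4 (0.80 log units; beyond the scatter). Compound 4 is estimated at 120 nM, with a likely range from 40 nM to 400 nM.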

Compound 4, half-maximal inhibitory concentration: 18.1 nM
For compound 4 the middle estimate is 6.6-fold (0.82 log units) above the measured one, and the stated range ends above it.
By their numbers in this assay, from the lowest: compound 1; then compound 4; then compound 2; then compound 3.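

Taking the carboxy off the five-membered ring lowers the number sharply (a 42-fold lower number from compound 3 to compound 4 (1.62 log units; beyond the scatter)), so 5-carboxyfuran-2-yl is much weaker here than furan-2-yl. Furan-2-yl also beats 1H-pyrrol-2-yl in a direct comparison (an 11-fold lower number from compound 2 to compound 4 (1.03 log units; beyond the scatter)). The step on the amine nitrogen, hydrogen in place of 2-hydroxyethyl, is smaller (a 2.2-fold higher number from compound 1 to compound 4 (0.34 log units; beyond the scatter)).

Going by these compounds, whether a methyl ester or a carboxamide on that same aromatic carbon would behave like the carboxy remains open. Nothing measured here explains these steps.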